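Chloro in place of methyl on the series core

The source may report more compounds than this note shows. Statements on the series, on what has been measured and on what is new or still open speak of the compounds shown alone.

Compound 1 `COc1cc(/C=C/C(=O)/C=C/c2nc3cc(C)ccc3n2C)ccc1O` gives 7700 nM in a functional assay on NCI-H460 cells (Homo sapiens) for cytotoxicity, read by MTT assay, with a stated time of 48 h (a lower number here means a stronger inhibitor, a higher number a weaker inhibitor), and stands second highest of three numbers. Compound 2 `COc1cc(/C=C/C(=O)/C=C/c2nc3c(C)cccc3n2C)ccc1O` lies lower at 3000 nM while compound 3 `COc1cc(/C=C/C(=O)/C=C/c2nc3c(C)c(C)ccc3n2C)ccc1O` lies highest at 31900 nM in this small set.

Compound 4 `COc1cc(/C=C/C(=O)/C=C/c2nc3cc(Cl)ccc3n2C)ccc1O` is not yet measured. It differs from compound 1 by chloro in place of methyl on an aromatic carbon on the same core.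

Among the measured compounds shown here, no measured step exchanges these two groups. The closest evidence is methyl in place of hydrogen on an aromatic carbon, seen as a 4.1-fold higher number from compound 1 to compound 3 (0.62 log units; beyond the scatter) (modest) and an 11-fold higher number from compound 2 to compound 3 (1.03 log units; beyond the scatter) (large). Both steps raise the number, so the read-out clearly responds to substitution on the core, yet neither gives a direction for this exchange.

The expected result is a 1.1-fold lower number from compound 1 to compound 4 (0.04 log units; within the scatter) (no step beyond the scatter, with wide uncertainty). The estimate for compound 4 is 7000 nM (range 2500 nM to 20000 nM).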

Compound 4, half-maximal inhibitory concentration: 8900 nM
Estimate against measurement, compound 4: 1.3-fold (0.10 log units) below; the measured number falls inside the stated range.
By their numbers in this assay, from the lowest: compound 2; then compounds 1 and 4 (each within the scatter of the next); then compound 3.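

Chloro in place of methyl on this aromatic carbon gives a 1.2-fold higher number from compound 1 to compound 4 (0.06 log units; within the scatter) in this assay and so offers a direct reading of an exchange at this position. The earlier steps shown here each added a methyl and moved the number beyond the scatter, whereas here one single-atom group replaces another and compound 1 and compound 4 cannot be told apart. No measured property of either group is available to bear on this result.

On these data alone, whether an amine, a carboxylic acid or a longer alkyl chain on this same aromatic carbon would also leave the number unchanged stays open. Also open, as far as these compounds go, is whether chloro in place of methyl would read the same on the aromatic carbon that carries methyl in compound 2.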